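A hydroxy group on the ethyl amide chain

The compounds below may be only part of what the source reports. "The series", "measured", "known", "first", "only" and "open" are said of these compounds alone.

Measured in a functional assay on HUVEC cells (Homo sapiens) for inhibition, with a stated time of 4 days; a lower number here means a stronger inhibitor, a higher number a weaker inhibitor:
- compound 1 `COc1ccc(C(=O)N(C)C)cc1/C=C/c1ccc(Cl)cc1`: 2500 nM
- compound 2 `CCNC(=O)c1ccc(OC)c(/C=C/c2ccc(Cl)cc2)c1`: 160 nM

Going by the values given here, of the two numbers so far, the lower belongs to compound 2, at 160 nM, which makes it the stronger inhibitor of the pair. Compound 3 `COc1ccc(C(=O)NCCO)cc1/C=C/c1ccc(Cl)cc1` keeps the shared core of compound 2 and alters only the amide chain: hydroxy in place of hydrogen on a saturated chain carbon, two bonds along the chain from an amide-type nitrogen. In words, hydroxy stands in place of hydrogen on a saturated chain carbon, two bonds along the chain from an amide-type nitrogen.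

Among the compounds with values here, only one measured step bears on this change: a 16-fold lower number from compound 1 to compound 2 (1.19 log units; beyond the scatter), which replaced dimethylamino with ethylamino on a carbonyl carbon. This large step shows that this assay can respond strongly to a change in the group on that carbonyl carbon. However, it rests on a single pair, and no measured compound carries a hydroxy group. A moderate step towards a higher number, smaller than the measured one, is therefore expected. The expected change is a 2.5-fold higher number from compound 2 to compound 3 (0.40 log units; beyond the scatter). For compound 3 the estimated value is 400 nM, with an expected range from 120 nM to 1500 nM.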

Compound 3, half-maximal inhibitory concentration in the HUVEC assay: 910 nM
For compound 3 the middle estimate is 2.3-fold (0.36 log units) below the measured one; low and high end bracket the measured number.
By their numbers in the HUVEC assay, from the lowest: compound 2; then compound 3; then compound 1.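

In the HUVEC assay, hydroxy in place of hydrogen on a saturated chain carbon, two bonds along the chain from an amide-type nitrogen, brings a 5.7-fold higher number from compound 2 to compound 3 (0.75 log units; beyond the scatter) and so weakens inhibition, which shows that the far end of the ethyl chain is sensitive to substitution, something the earlier pair, which differed only in the group on the carbonyl carbon, could not reveal. The (2-hydroxyethyl)amino compound nevertheless remains on the stronger side of the dimethylamino compound in the HUVEC assay with a 2.7-fold lower number from compound 1 to compound 3 (0.44 log units; beyond the scatter) and thus keeps part of the advantage seen for the ethylamino group. In a physicochemical assay for solubility, read by HPLC, in simulated intestinal fluid, with a stated time of 2 h, tested at 10 mM (a lower number here means a less soluble compound, a higher number a more soluble compound), compound 2 gives 9 ug/mL and compound 3 gives 16 ug/mL as two values within the usual scatter of each other, so this read-out does not separate the pair.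

No measurement shown here explains the weaker inhibition of compound 3. Going by these compounds, it remains open whether the loss is particular to the hydroxy group or would also follow from a methoxy group, an amine or a carboxylic acid at the end of the chain, or from a longer chain such as 3-hydroxypropyl.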